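Phenyl for cyclohexyl on the ring nitrogen of the core

The source may hold more compounds than are shown below. What is called first, only, known or untested is meant among the compounds shown, and "the series" means these compounds.

Measured compounds:
compound 1 `CN1C(=S)N(c2ccccc2)C(=O)/C1=C\c1ccc(N(C)C)cc1O`, 3430 nM
compound 2 `CCN(CC)c1ccc(/C=C2\C(=O)N(C3CCCCC3)C(=S)N2C)c(O)c1`, 2350 nM

In an assay on isolated protein for inhibition of NADPH oxidase 4 (Homo sapiens), read by chemiluminescence, in the presence of a further agent that is not named here (on this read-out higher numbers stand for weaker inhibition and lower numbers for stronger inhibition), compound 1 gives 3430 nM and compound 2 gives 2350 nM. Compound 2 holds the lower of the two numbers, but the gap to compound 1 is within the scatter, so the two cannot be told apart on this assay. For the measured compounds named here, compound 1 and compound 2 differ in more than one place, so no single step between them is available.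

Compound 3 `CCN(CC)c1ccc(/C=C2\C(=O)N(c3ccccc3)C(=S)N2C)c(O)c1` is not yet measured. It differs from compound 2 in one place: phenyl in place of cyclohexyl on an amide-type nitrogen in a ring. Going by the values given here, no measured step isolates this change; on the two numbers in hand, both of which sit close together, no step beyond the scatter is expected in either direction. Compound 3 is therefore estimated at 3000 nM, with a range of 1200 nM to 7500 nM, which corresponds to an expected step of a 1.3-fold higher number from compound 2 to compound 3 (0.11 log units; within the scatter).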

Compound 3, half-maximal inhibitory concentration: 1100 nM
Estimate against measurement, compound 3: 2.7-fold (0.44 log units) above, and the stated range ends above it.
By their numbers in this assay, from the lowest: compound 3; then compounds 2 and 1 (each within the scatter of the next).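

In this assay, the amide-type nitrogen in a ring proves sensitive to the nature of its six-carbon ring: phenyl in place of cyclohexyl, with the same heavy-atom count and no donors or acceptors on either group, gives a 2.1-fold lower number from compound 2 to compound 3 (0.33 log units; beyond the scatter). The aromatic carbon bearing the amine is a second point of sensitivity, since diethylamino in place of dimethylamino gives a 3.1-fold lower number from compound 1 to compound 3 (0.49 log units; beyond the scatter), so the closeness of compound 1 and compound 2 concealed two separate one-place steps. No measurement on hand accounts for either step.

Still open, going by these compounds, is whether a benzyl group or a pyridyl ring on the amide-type nitrogen in a ring would extend the first step. Also open, on these data alone, is whether dipropylamino or pyrrolidinyl on the aromatic carbon would extend the second.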